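Benzoyl Ester in Place of Chlorobenzyl Ether on the Core

The compounds below may be only part of what the source reports. "The series", "measured", "known", "first", "only" and "open" are said of these compounds alone.

Compound 1 `CCC1(Cc2ccccc2)OS(=O)(=O)C=C1OCCCCc1ccccc1`: >= 20000 nM
Compound 2 `CCC1(Cc2ccccc2)OS(=O)(=O)C=C1OCc1ccc(Cl)cc1`: >= 50000 nM

Both measured compounds share one core and differ only in the group carried on the oxygen attached to the unsaturated carbon. In an ADME assay on HEL cells (Homo sapiens) for cytotoxicity, with a stated time of 3 days (on this read-out lower numbers stand for higher toxicity in this test and higher numbers for lower toxicity in this test), compound 1 gives >= 20000 nM, which is a limit of the test and not a number. In this assay compound 2 gives >= 50000 nM, again a limit. The step that the two limits leave unreadable from compound 1 to compound 2 therefore cannot be read in size or direction: one value sits at the limit of >= 20000 nM in this assay, at which 1 of the 2 values shown sits, and the other at the limit of >= 50000 nM in this assay, at which 1 of the 2 values shown sits, so all that is known is that neither compound reached a measurable toxic concentration.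

Compound 3 `CCC1(Cc2ccccc2)OS(=O)(=O)C=C1OC(=O)c1ccccc1` is the next compound, differing from compound 2 by benzoyl in place of 4-chlorobenzyl on an oxygen on an unsaturated carbon. Going by the values given here, no measured step covers an ester in place of an ether at this position, so the only guide is that compound 2 stands at a limit. Compound 3 is expected to behave alike, with an estimated step of a number no higher from compound 2 to compound 3 (the limit leaves the size open) that stays within the scatter. The estimate for compound 3 is 50000 nM, in a range from 20000 nM to 100000 nM, most likely reported again as a limit.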

Compound 3, minimum cytotoxic concentration: > 400000 nM
Compound 3 was reported as a limit; the forecaster's own chance of this, stated with the estimate: 75%; middle value at least 8.0-fold (0.90 log units) from the limit.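

In this assay compound 3 gives > 400000 nM, which is a limit of the test and not a number. Compound 2 also stands at a limit, so the step from compound 2 to compound 3 cannot be read in size or direction. The compounds shown leave open whether benzoyl or 4-chlorobenzyl gives lower toxicity in this test.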